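The source may report more compounds than this note shows. Statements on the series, on what has been measured and on what is new or still open speak of the compounds shown alone.

Values so far from a functional assay on J774 cells (Mus musculus) for cytotoxicity, read by resazurin assay; on this read-out lower numbers stand for stronger inhibition and higher numbers for weaker inhibition
Compound 1 `OCCCCCC(O)c1ccc(-c2ccc(Br)cc2)cc1` gives 20000 nM
Compound 2 `Cc1ccc(-c2ccc(C(O)CCCCCO)cc2)cc1` gives 22000 nM
Compound 3 `OCCCCCC(O)c1ccc(-c2ccc(O)cc2)cc1` gives 15000 nM

Compound 3, at 15000 nM in this assay, lies within the scatter of both other compounds. Compound 4 `OCCCCCC(O)c1ccc(-c2ccc(C(F)(F)F)cc2)cc1` replaces hydroxy with trifluoromethyl on an aromatic carbon, a change counted as trifluoromethyl in place of hydroxy on an aromatic carbon with the shared core left as it is. The measured swaps at that same place are small: a 1.3-fold lower number from compound 1 to compound 3 (0.12 log units; within the scatter) and a 1.5-fold lower number from compound 2 to compound 3 (0.17 log units; within the scatter) while a 1.1-fold higher number from compound 1 to compound 2 (0.04 log units; within the scatter) likewise stays within the scatter. Among the compounds with values here, no trifluoromethyl compound has been measured, so these steps are only a guide. The expected step is a 1.3-fold higher number from compound 3 to compound 4 (0.12 log units; within the scatter) and no move beyond the scatter is expected. For compound 4 the estimate is 20000 nM with an expected range from 11000 nM to 35000 nM in this read-out.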

Compound 4, half-maximal inhibitory concentration: 13000 nM
Compound 4: middle estimate off by 1.5-fold (0.19 log units), on the high side, and the stated range covers the measured number.
By their numbers in this assay, from the lowest: compounds 4, 3, 1 and 2 (each within the scatter of the next).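

In this assay, trifluoromethyl on an aromatic carbon para to a large group joins hydroxy, methyl and bromo within the scatter: a 1.2-fold lower number from compound 3 to compound 4 (0.06 log units; within the scatter), a 1.7-fold lower number from compound 2 to compound 4 (0.23 log units; within the scatter) and a 1.5-fold lower number from compound 1 to compound 4 (0.19 log units; within the scatter). Trifluoromethyl, with 4 heavy atoms and no hydrogen-bond donor or acceptor, thus reads like hydroxy, which carries one of each, and this position has so far shown no step beyond the scatter. Nothing available bears on why this is so.

On these data alone, whether an amine or a carboxylic acid at this place would move the number beyond the scatter stays open. So does the effect of a longer chain on the shared core.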